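A few compounds are considered here, and "the series" means these few. Any claim that something is new, unique, unknown or untested is made for them only; others in the source may bear on it.

Measured compounds in a functional assay on NIH3T3 cells (Mus musculus); a higher number here means that more compound is needed for the effect, a lower number that less compound is needed:
Compound 1 `CSCNC(=O)c1ccc(NCc2cncn2Cc2ccc(C#N)cc2)cc1-c1ccccc1` gives > 10 uM, a limit of the assay.
Compound 2 `N#Cc1ccc(Cn2cncc2CNc2ccc(C(=O)NCc3ccccc3)c(-c3ccccc3)c2)cc1` gives > 10 uM, likewise a limit of the assay.
Compound 3 `CSCC[C@H](NC(=O)c1ccc(NCc2cncn2Cc2ccc(C#N)cc2)cc1-c1ccccc1)C(=O)O` gives > 10 uM, again a limit of the assay.

All three measured values sit at the limit of > 10 uM in this assay, at which 3 of the 3 values shown sit, so compound 3 stands nowhere distinguishable from compounds 1 and 2 on the numbers shown. The three measured steps, a step that the two limits leave unreadable from compound 1 to compound 2, a step that the two limits leave unreadable from compound 1 to compound 3 and a step that the two limits leave unreadable from compound 2 to compound 3, are each left unreadable by the two limits, so none of them gives a size or a direction for a change on the amide-type nitrogen.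

Compound 4 `N#CCNC(=O)c1ccc(NCc2cncn2Cc2ccc(C#N)cc2)cc1-c1ccccc1` is the next member. Its difference from compound 3 is cyanomethyl in place of 1-carboxy-3-(methylsulfanyl)propyl on an amide-type nitrogen. Within the data shown here, the steps that bear on this position, those among compounds 1, 2 and 3, are all unreadable, and no measured value gives a number to anchor an expectation. The expected step that the limit leaves unreadable from compound 3 to compound 4 is therefore set at no change beyond the scatter, with wide uncertainty. Compound 4 is estimated at 20 uM, with a range from 5 uM to 100 uM, and most likely the assay again reports only a limit.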

Compound 4, concentration for half-maximal effect: > 10 uM
Compound 4 was reported as a limit (the forecaster's own chance of this, stated with the estimate: 80%); the middle value is on the limit's open side.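

Among these compounds, no step from compound 1, compound 2 or compound 3 to compound 4 can be read, because all four values are limits of the assay: the limit of > 10 uM in this assay, at which 4 of the 4 values shown sit.
The compounds shown leave open whether any group on the amide-type nitrogen changes the result in this assay at all, and in which direction.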